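Fluoro for Chloro on a Sulfonamide Tetralin Core

The source may hold more compounds than are shown below. What is called first, only, known or untested is meant among the compounds shown, and "the series" means these compounds.

The series rests on a shared core carrying an imidazole and a sulfonamide on a fused aromatic ring. Compound 1 `CS(=O)(=O)Nc1ccc(Cl)c2c1CCCC2c1c[nH]cn1` is the weakest member among the three measured: in a functional assay on Urethra for agonist activity at Alpha-1A adrenergic receptor (Oryctolagus cuniculus) (on this read-out lower numbers stand for lower potency and higher numbers for higher potency (the scale is a negative logarithm)), compound 1 gives 4.35. Its nearest neighbour in this assay is compound 2 `CCS(=O)(=O)Nc1cccc2c1CCC2c1c[nH]cn1`, which gives 7.18, a value well beyond the scatter above compound 1. Compound 3 `CS(=O)(=O)Nc1c(O)ccc2c1CCCC2c1c[nH]cn1` stands furthest from compound 1; in this assay compound 3 gives 7.77, again beyond the scatter. No two of the measured compounds differ in only one place, so no single-point step can be read directly from the numbers.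

Compound 4 `CS(=O)(=O)Nc1ccc(F)c2c1CCCC2c1c[nH]cn1` has not yet been measured. It differs from compound 1 in a single way: fluoro in place of chloro on an aromatic carbon. For the measured compounds named here, with no measured step to lean on, the size of the change is uncertain. A modest upward step is expected, close to the usual scatter in this assay, a number 0.65 log units higher from compound 1 to compound 4 (beyond the scatter), because compound 1 starts from 4.35 and the other measured compounds sit far higher. Compound 4 is therefore estimated at 5 in this assay, within a range from 4.2 to 6.2.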

Compound 4, negative logarithm of the half-maximal effective concentration: 5.31
The estimate for compound 4 lay 0.31 log units below the measured number; low and high end bracket the measured number.
By their numbers in this assay, from the lowest: compound 1; then compound 4; then compound 2; then compound 3.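

Fluoro in place of chloro on an aromatic carbon, para to a methanesulfonamido group, gives a number 0.96 log units higher from compound 1 to compound 4 (beyond the scatter) in this assay and provides the first step in this series that can be read at a single place. It shows that this position is not silent: the exchange of one halogen for another moves the read-out beyond the scatter, even though the two groups match in heavy-atom count, carry no hydrogen-bond donors or acceptors, and bear no net charge. Nothing measured here accounts for the size or direction of this step.

The compounds shown leave open how a bromo group, a methoxy group, an amine or a nitrile would read at this same place on the core of compound 1, and how the unsubstituted aromatic carbon would compare with either halogen. They also leave open whether the same exchange would give a step of similar size with a longer chain on the sulfonamide.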